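The compounds below may be only part of what the source reports. "The series", "measured", "known", "first", "only" and "open" are said of these compounds alone.

Working notes on the series in a functional assay on HepG2 cells (Homo sapiens) for antiproliferative activity, read by MTT assay, with a stated time of 48 h; on this read-out higher numbers stand for weaker inhibition and lower numbers for stronger inhibition. Compound 1 `O=C(/C=C/c1ccc(O)cc1)Nc1cc2c(Nc3ccc(Cl)c(Cl)c3)ncnc2s1` gives 42900 nM in this read-out, compound 2 `COc1ccc(/C=C/C(=O)Nc2cc3c(Nc4ccc(Cl)c(Cl)c4)ncnc3s2)cc1` gives 30600 nM and compound 3 `O=C(/C=C/c1ccccc1)Nc1cc2c(Nc3ccc(Cl)c(Cl)c3)ncnc2s1` gives 30100 nM. Compound 2 therefore lies within the scatter of both other compounds, and the three numbers cannot be ranked. The measured steps are a 1.4-fold lower number from compound 1 to compound 2 (0.15 log units; within the scatter), a 1.4-fold lower number from compound 1 to compound 3 (0.15 log units; within the scatter) and a 1.0-fold lower number from compound 2 to compound 3 (0.01 log units; within the scatter), all within the scatter. They exchange only hydroxy, methoxy and hydrogen on an aromatic ring, and all three compounds carry the same 3,4-dichlorophenyl group.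

Compound 4 `COc1ccc(/C=C/C(=O)Nc2cc3c(Nc4cc(Cl)cc(Cl)c4)ncnc3s2)cc1` keeps the methoxy group of compound 2 and changes the other end of the molecule: 3,5-dichlorophenyl in place of 3,4-dichlorophenyl on a nitrogen on an aromatic ring. In words, this is 3,5-dichlorophenyl in place of 3,4-dichlorophenyl on a nitrogen on an aromatic ring. Among the measured compounds shown here, no measured step tests this exchange, so the steps above bear on it only indirectly, showing a flat series for changes made elsewhere. With no direct evidence for a direction, no step beyond the scatter is expected in this assay, and the expectation stays anchored on compound 2 at 30600 nM. The estimate means an expected 1.0-fold lower number from compound 2 to compound 4 (0.01 log units; within the scatter). For compound 4 the estimated value is 30000 nM, with an expected range from 13000 nM to 60000 nM.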

Compound 4, half-maximal inhibitory concentration: 41800 nM
Beside the measured number, compound 4's estimate is 1.4-fold (0.14 log units) below it, within the range that was stated.
By their numbers in this assay, from the lowest: compounds 3, 2, 4 and 1 (each within the scatter of the next).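

Among the compounds shown here, the earlier compounds varied only the hydroxy, methoxy and hydrogen end of the molecule, so this is the first reading on the group on a nitrogen on an aromatic ring: in this assay, 3,5-dichlorophenyl in place of 3,4-dichlorophenyl gives a 1.4-fold higher number from compound 2 to compound 4 (0.14 log units; within the scatter). The two groups hold the same atoms joined differently, and with the methoxy group in place this read-out does not tell them apart, so the flat picture now extends to both ends of the molecule across these four compounds. Nothing on hand gives a reason for this result or a measured property of either group.

As far as these compounds go, the exchange is read only on the methoxy compounds, so whether it stays within the scatter with hydroxy or hydrogen at the other end remains open. Also open, from the compounds shown here alone, is whether a step beyond the scatter appears with a different group on that nitrogen, such as a phenyl carrying a single chlorine or a trifluoromethyl group, or with an amine or a carboxylic acid on the other aromatic ring.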